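Chain amines on the shared core: compound 3 to compound 4

This account rests on a few compounds, and the source may have more. Where it says the series, first, only, none or still open, it means among the compounds named here.

Measured in a functional assay on DU-145 cells (Homo sapiens) for antiproliferative activity, read by WST assay, with a stated time of 3 days; a lower number here means a stronger inhibitor, a higher number a weaker inhibitor:
- compound 1 `CCCCOc1c(-c2cc(OC)c(OC)c(OC)c2)oc2ccccc2c1=O`: > 50000 nM, a limit of the assay and not a number
- compound 2 `CCN(CC)CCCCOc1c(-c2cc(OC)c(OC)c(OC)c2)oc2ccccc2c1=O`: 13300 nM
- compound 3 `CCN(CC)CCCCCOc1c(-c2cc(OC)c(OC)c(OC)c2)oc2ccccc2c1=O`: 33400 nM

Of the two numeric values, the higher belongs to compound 3 at 33400 nM. The nearest is compound 2 at 13300 nM.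

Next is compound 4 `CCCN(CCC)CCCCOc1c(-c2cc(OC)c(OC)c(OC)c2)oc2ccccc2c1=O`. Its difference from compound 3 is dipropylamino in place of (diethylamino)methyl on a saturated chain carbon, four bonds along the chain from an oxygen on an aromatic ring.

The most relevant measured step is a 2.5-fold higher number from compound 2 to compound 3 (0.40 log units; beyond the scatter), with (diethylamino)methyl in place of diethylamino at that same place. Two further steps add context. Diethylamino gave an at least 3.7-fold lower number from compound 1 to compound 2 (0.57 log units; beyond the scatter), and (diethylamino)methyl gave an at least 1.4-fold lower number from compound 1 to compound 3 (0.17 log units; that floor lies within the scatter), whose floor lies within the scatter. Dipropylamino, like diethylamino, stands directly on that chain carbon, so a step of similar modest size toward a lower number is expected in this assay, on the basis of a 2.5-fold higher number from compound 2 to compound 3 (0.40 log units; beyond the scatter). Within the data shown here, with only three compounds behind it, this expectation remains loose.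

The expected change is a 2.2-fold lower number from compound 3 to compound 4 (0.35 log units; beyond the scatter). For compound 4 the estimated value is 15000 nM, with an expected range of 5000 nM to 40000 nM.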

Compound 4, half-maximal inhibitory concentration: 35800 nM
For compound 4 the middle estimate is 2.4-fold (0.38 log units) below the measured one, within the range that was stated.
By their numbers in this assay, from the lowest: compound 2; then compounds 3 and 4 (each within the scatter of the next). At a limit, above all of these: compound 1.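

In this assay, dipropylamino in place of diethylamino on the same chain carbon is a real loss, with a 2.7-fold higher number from compound 2 to compound 4 (0.43 log units; beyond the scatter), so at this place the result depends on the alkyl groups on the nitrogen as well as on the chain that carries it. Dipropylamino and (diethylamino)methyl cannot be told apart, with a 1.1-fold higher number from compound 3 to compound 4 (0.03 log units; within the scatter), which leaves compound 2 as the only one of the three amines set apart from the other two, while an at least 1.3-fold lower number from compound 1 to compound 4 (0.14 log units; that floor lies within the scatter) gives only a floor for what the amine adds in compound 4. That floor rests on compound 1, whose entry is a limit of the assay and not a number: the limit of > 50000 nM in this assay, at which 1 of the 4 values shown sits.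

As far as these compounds go, whether a smaller amine such as dimethylamino, or a ring amine such as piperidine or morpholine, at this place would give a lower number than compound 2 stays open. Also open, from the compounds shown here alone, is how dipropylamino behaves on the chain of compound 3, which would show whether the two changes seen here add together.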